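This account rests on a few compounds, and the source may have more. Where it says the series, first, only, none or still open, it means among the compounds named here.

Three close relatives have been tested so far in a functional assay on FaDu cells (Homo sapiens) for cytotoxicity, read by MTT assay, with a stated time of 72 h; a lower number here means that less compound is tolerated, a higher number that more compound is tolerated. Compound 2 (`COc1ccc(NC(=O)C(=O)c2cn(CC(C)(C)OC)c3ccccc23)cn1`) gives > 10000 nM there, which is a limit of the assay and not a number. Compound 3 (`COc1ccc(NC(=O)C(=O)c2cn(C(C)C)c3c(OC)cccc23)cn1`) gives > 10000 nM in this assay, which is also a limit. Going by the values given here, compound 1 (`COc1ccc(NC(=O)C(=O)c2cn(C(C)C)c3c(Cl)cccc23)cn1`) gives 10200 nM in this assay, the only true number of the three. As far as these compounds go, compound 2 therefore stands at the limit of > 10000 nM in this assay, at which 2 of the 3 values shown sit, and its exact value is unknown.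

Compound 4 (`COc1ccc(NC(=O)C(=O)c2cn(CC(C)C)c3ccccc23)cn1`) differs from compound 2 by a single change, hydrogen in place of methoxy on a saturated chain carbon bound to three saturated chain carbons, which turns 2-methoxy-2-methylpropyl into isobutyl: hydrogen in place of methoxy on a saturated chain carbon bound to three saturated chain carbons. Among the compounds with values here, the only measured single change, a step that the limit leaves unreadable from compound 1 to compound 3, is methoxy in place of chloro on an aromatic carbon, so it is a different change and offers no size to carry over. Within the data shown here, compound 1 at 10200 nM is the one number to lean on, so compound 4 is expected to stay near that level. No shift beyond the usual scatter is expected in this assay, and no direction can be given. The expectation is therefore a number no higher from compound 2 to compound 4 (the limit leaves the size open), and a limit is about as likely as a number. For compound 4 the estimated value is 10000 nM, with an expected range from 3500 nM to 30000 nM.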

Compound 4, concentration lethal to 50% of the cells: 317 nM
Beside the measured number, compound 4's estimate is 32-fold (1.50 log units) above it, outside the stated range (below it).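

Going by these compounds alone, until now no step could be read, since the one earlier change, on an aromatic carbon, has its size hidden by a limit. In this assay, turning 2-methoxy-2-methylpropyl into isobutyl now gives an at least 31-fold lower number from compound 2 to compound 4 (1.49 log units; beyond the scatter), so a single swap of methoxy for hydrogen on a saturated chain carbon bound to three saturated chain carbons is enough to move the cells from tolerating everything tested to tolerating far less, and this side chain proves to be a place where the read-out responds strongly. The full size of that step stays unknown, because compound 2 carries only a limit of the assay and not a number: the limit of > 10000 nM in this assay, at which 2 of the 4 values shown sit.

The compounds shown do not tell whether the methoxy is unique in this effect or whether other groups on the same carbon, such as a hydroxyl, an amine or a carboxylic acid, would also keep the number high. They also leave open how far the chain itself can vary, since a longer chain in place of isobutyl has no value here, and whether a chloro or methoxy on the aromatic carbon would change the number of compound 4.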